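Compound 3 to compound 4: chain out, ring in

The source may report more compounds than this note shows. Statements on the series, on what has been measured and on what is new or still open speak of the compounds shown alone.

Measured so far in a functional assay on HCT-116 cells (Homo sapiens) for antiproliferative activity, read by MTT assay, with a stated time of 48 h; on this read-out lower numbers stand for stronger inhibition and higher numbers for weaker inhibition:
- compound 1 `Cc1c(C(=O)NCC(O)CO)oc2ccc(N(Cc3ccc(Br)cc3)S(=O)(=O)c3ccc(Br)cc3)cc12` gives 27800 nM
- compound 2 `CN(C)CCNC(=O)c1nc2cc(N(Cc3ccc(Br)cc3)S(=O)(=O)c3ccc(Br)cc3)ccc2o1` gives 14300 nM
- compound 3 `CCN(CC)CCNC(=O)c1nc2cc(N(Cc3ccc(Br)cc3)S(=O)(=O)c3ccc(Br)cc3)ccc2o1` gives 14300 nM

Compound 3 stands level with compound 2 at the digits shown, and compound 1 lies within the usual scatter of compound 3, so these numbers do not separate the three compounds.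

The next compound, compound 4 `CN1CCC(NC(=O)c2nc3cc(N(Cc4ccc(Br)cc4)S(=O)(=O)c4ccc(Br)cc4)ccc3o2)CC1`, keeps the shared core of compound 3 and changes only the group on the amide-type nitrogen. The change is 1-methylpiperidin-4-yl in place of 2-(diethylamino)ethyl on an amide-type nitrogen, so a group with no ring gives way to one with a six-membered non-aromatic ring.

Going by the values given here, one measured step bears on this directly. It is no change at the digits printed from compound 2 to compound 3 (within the scatter), and it altered the same side group without moving the number. Compound 1, with another core and another amide group, gives 27800 nM and still falls within the scatter of compound 3. Among the compounds with values here, no measured compound carries a ring on this amide-type nitrogen, however, so the evidence is indirect.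

The expected change is small, with a 1.0-fold lower number from compound 3 to compound 4 (0.01 log units; within the scatter) estimated and no direction expected beyond the scatter. For compound 4 the estimated value is 14000 nM, with an expected range from 7000 nM to 30000 nM in this assay.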

Compound 4, half-maximal inhibitory concentration: 7320 nM
For compound 4 the middle estimate is 1.9-fold (0.28 log units) above the measured one; the range from low to high includes it.
By their numbers in this assay, from the lowest: compounds 4, 2, 3 and 1 (each within the scatter of the next, the first and the last beyond it).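

Going by these compounds alone, compound 4 is the first measured compound with a ring on this amide-type nitrogen, and 1-methylpiperidin-4-yl has the same counted heavy atoms as 2-(diethylamino)ethyl, arranged as a six-membered non-aromatic ring rather than an open chain. In this assay that exchange gives a 2.0-fold lower number from compound 3 to compound 4 (0.29 log units; within the scatter), and replacing 2-(dimethylamino)ethyl with the same ring gives a 2.0-fold lower number from compound 2 to compound 4 (0.29 log units; within the scatter), so both steps stay within the usual scatter and neither establishes a real gain or loss. At this position, therefore, a ring can take the place of either open chain without a change that these numbers can separate from assay scatter, and no supporting measurement is available to explain the result.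

From the compounds shown here alone, it remains open whether this holds for other groups on the same nitrogen, such as cyclohexyl, which has no ring nitrogen, or piperidin-4-yl, which lacks the methyl group. A longer chain ending in an amine, or a carboxylic acid in place of that amine, could also show whether any group here moves the number beyond the scatter.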